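Swapping the Sulfonyl Aryl Group of a Potent Antagonist

The source may hold more compounds than are shown below. What is called first, only, known or untested is meant among the compounds shown, and "the series" means these compounds.

Of the compounds shown here, three sharing a common core have been tested in an assay on isolated protein for displacement of a labelled ligand from prostaglandin E2 receptor EP3 subtype (Homo sapiens), read by scintillation counting, with a stated time of 2 h; a higher number here means a weaker inhibitor, a lower number a stronger inhibitor. Compound 1 `O=C(NC/C=C1\CCCc2cnn(Cc3ccc(Cl)cc3Cl)c21)NS(=O)(=O)c1cc(Cl)c(Cl)s1` gives 0.5 nM in this assay, the lowest of the three numbers. Going by the values given here, compound 2 `CS(=O)(=O)c1ccc(-n2ncc3c2/C(=C/CNC(=O)NS(=O)(=O)c2cc(Cl)c(Cl)s2)CCC3)cc1` gives 1 nM in this assay, and the only single-point step among the measured compounds is a 2.0-fold higher number from compound 1 to compound 2 (0.30 log units; within the scatter), a change of 4-(methylsulfonyl)phenyl in place of 2,4-dichlorobenzyl on an aromatic nitrogen. Compound 3 `O=C(NC/C(F)=C1\CCCc2cnn(C3CCN(c4ccc(F)cc4)CC3)c21)NS(=O)(=O)c1cc(Cl)c(Cl)s1` differs from compound 1 at several places at once. In this assay compound 3 gives 13 nM, the highest of the three.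

The step of interest leads from compound 1 to compound 4 `COc1ccc(Cl)cc1S(=O)(=O)NC(=O)NC/C=C1\CCCc2cnn(Cc3ccc(Cl)cc3Cl)c21`, which has not yet been measured. The change is 5-chloro-2-methoxyphenyl in place of 4,5-dichlorothiophen-2-yl on a sulfonyl sulfur. This alters the group on the sulfonyl sulfur, a part of the molecule left untouched in every measured step: the step from compound 1 to compound 2 changes the group on the aromatic nitrogen instead, and compound 3 differs from compound 1 at several places at once. Among the compounds with values here, no measured step therefore bears directly on this change, and the expectation rests only on the fact that the rest of the molecule is kept while the aromatic ring on the sulfonyl sulfur is exchanged. A moderate weakening is expected, a 4.0-fold higher number from compound 1 to compound 4 (0.60 log units; beyond the scatter), rather than none beyond the scatter. Compound 4 is thus estimated at 2 nM in this assay, within a range from 0.5 nM to 10 nM.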

Compound 4, inhibition constant: 3 nM
Compound 4: the middle estimate sits 1.5-fold (0.18 log units) below what was measured; low and high end bracket the measured number.
By their numbers in this assay, from the lowest: compounds 1 and 2 (each within the scatter of the next); then compound 4; then compound 3.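

Going by these compounds alone, exchanging 4,5-dichlorothiophen-2-yl for 5-chloro-2-methoxyphenyl on the sulfonyl sulfur gives, in this assay, a 6.0-fold higher number from compound 1 to compound 4 (0.78 log units; beyond the scatter) and shows that the group at this position affects the result, whereas the one earlier single-place step, on the aromatic nitrogen, stayed within the scatter at a 2.0-fold higher number from compound 1 to compound 2 (0.30 log units; within the scatter). The effect is modest, however, and compound 4 still gives 3 nM with a six-membered carbon-only ring in the place of a five-membered ring containing a hetero atom, so this position does not depend strictly on the thiophene ring. Ring size, ring atoms and the groups on the ring all change in this one step, so the compounds cannot show which of these differences matters, and no supporting data explain the change.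

The compounds shown leave open whether a plain phenyl ring, an unsubstituted thiophen-2-yl group or a small alkyl group such as methyl would be accepted on the sulfonyl sulfur. They also do not show how 5-chloro-2-methoxyphenyl on the sulfonyl sulfur would behave when combined with 4-(methylsulfonyl)phenyl on the aromatic nitrogen.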